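Compound 1 at the limit: exchanging the benzimidazole group

The source may hold more compounds than are shown below. What is called first, only, known or untested is meant among the compounds shown, and "the series" means these compounds.

In a functional assay on K562 cells (Homo sapiens) for antiproliferative activity, read by MTT assay, with a stated time of 48 h (a lower number here means a stronger inhibitor, a higher number a weaker inhibitor), compound 1 `CCN(CC)CCn1c(N)c(-c2nc3ccccc3n2C)c2nc(C#N)c(C#N)nc21` gives > 50000 nM, which is a limit of the assay and not a number. Compound 2 `CN(C)CCCCn1c(N)c(-c2nc3ccccc3n2C)c2nc(C#N)c(C#N)nc21` gives 1450 nM, and compound 3 `CCN(CC)CCCCn1c(N)c(-c2nc3ccccc3n2C)c2nc(C#N)c(C#N)nc21` gives 1010 nM. The two chain changes are large: an at least 34-fold lower number from compound 1 to compound 2 (1.53 log units; beyond the scatter) and an at least 49-fold lower number from compound 1 to compound 3 (1.69 log units; beyond the scatter). The amine change on the longer chain is not: a 1.4-fold lower number from compound 2 to compound 3 (0.16 log units; within the scatter).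

Compound 4 `CCN(CC)CCn1c(N)c(-c2nc3cc(Cl)ccc3[nH]2)c2nc(C#N)c(C#N)nc21` keeps the 2-(diethylamino)ethyl group of compound 1 and changes a different place on the shared core: 5-chloro-1H-benzimidazol-2-yl in place of 1-methyl-1H-benzimidazol-2-yl on an aromatic carbon. Here 5-chloro-1H-benzimidazol-2-yl stands in place of 1-methyl-1H-benzimidazol-2-yl on an aromatic carbon, next to the ring atom that bears an amino group.

Going by the values given here, none of the measured steps touches this carbon, so none gives the size of this change directly. The gain seen in an at least 49-fold lower number from compound 1 to compound 3 (1.69 log units; beyond the scatter) came with a chain change that compound 4 does not have, so a step of that size is not carried over. A moderate move towards a lower number is expected, and a result again at the limit remains possible. The estimated step is an at least 4.1-fold lower number from compound 1 to compound 4 (0.61 log units; beyond the scatter). For compound 4 the expected value in this assay is 12000 nM, with an estimated range of 2000 nM to 50000 nM.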

Compound 4, half-maximal inhibitory concentration: > 50000 nM
Compound 4 ended at the assay's limit (the forecaster's own chance of this, stated with the estimate: 30%); middle value at least 4.1-fold (0.61 log units) from the limit.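

No step can be read between compound 1 and compound 4, as both sit at a limit of this assay and not at a number: the limit of > 50000 nM in this assay, at which 2 of the 4 values shown sit.

The compounds shown leave open how far, and in which direction, 5-chloro-1H-benzimidazol-2-yl in place of 1-methyl-1H-benzimidazol-2-yl moves the number in this assay.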